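Working notes: a change on the aromatic nitrogen of compound 2

The source may report more compounds than this note shows. Statements on the series, on what has been measured and on what is new or still open speak of the compounds shown alone.

Measured in a functional assay on LNCaP cells (Homo sapiens) for cytotoxicity; a lower number here means a stronger inhibitor, a higher number a weaker inhibitor:
compound 1 `O=C(Nc1ccccc1)Nc1ccc(-c2nc(N3CC4CCC(C3)O4)c3cnn(C4CCC5(CC4)OCCO5)c3n2)cc1` gives 4 nM
compound 2 `CNC(=O)Nc1ccc(-c2nc(N3CC4CCC(C3)O4)c3cnn(C4CCC5(CC4)OCCCO5)c3n2)cc1` gives 8 nM
compound 3 `O=C(Nc1ccc(-c2nc(N3CC4CCC(C3)O4)c3cnn(C4CCC5(CC4)OCCO5)c3n2)cc1)Nc1cccnc1` gives 1 nM

Compound 2 holds the highest of the three numbers; its gap to compound 1 lies within the scatter, while compound 3 sits further off, beyond it. Within the data shown here, the only step between measured compounds, a 4.0-fold lower number from compound 1 to compound 3 (0.60 log units; beyond the scatter), sits on an amide-type nitrogen and not on the aromatic nitrogen. Compound 4 `CNC(=O)Nc1ccc(-c2nc(N3CC4CCC(C3)O4)c3cnn([C@H]4CC[C@H](O)CC4)c3n2)cc1` differs from compound 2 as follows: a group of 7 heavy atoms (6 carbon, 1 oxygen; one six-membered non-aromatic ring of carbon only) in place of a group of 11 heavy atoms (9 carbon, 2 oxygen; one six-membered non-aromatic ring of carbon only, one six-membered non-aromatic ring with 2 hetero atoms), on an aromatic nitrogen. Among the measured compounds shown here, no measured step touches this position. The expected step is accordingly one of no more than the scatter, a 1.3-fold lower number from compound 2 to compound 4 (0.12 log units; within the scatter). Compound 4 is estimated at 6 nM in this assay, with a range from 2 nM to 20 nM.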

Compound 4, half-maximal inhibitory concentration: 20 nM
Estimate against measurement, compound 4: 3.3-fold (0.52 log units) below; measured number inside the range.
By their numbers in this assay, from the lowest: compound 3; then compounds 1 and 2 (each within the scatter of the next); then compound 4.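

In this assay, among these compounds, the change to 4-hydroxycyclohexyl on the aromatic nitrogen brings a 2.5-fold higher number from compound 2 to compound 4 (0.40 log units; beyond the scatter) and gives the first measured step at this position, which is therefore not indifferent to the group it carries. The leaving group has two rings and no hydrogen-bond donor, while the entering group has one ring and one donor, so these differences change together in this single step. Nothing on hand gives a reason for the step.

From the compounds shown here alone, whether the hydroxyl itself matters stays open. An amine or a methoxy group on the cyclohexyl ring, or plain cyclohexyl, would separate it from the loss of the second ring.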